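The compounds below may be only part of what the source reports. "The series", "measured", "known", "first", "only" and "open" are said of these compounds alone.

Measured compounds in the series:

Compound 1, `CC(C)N(Cc1cccc(OCCCCCC(=O)O)c1)C(=O)c1ccccc1`, in an ADME assay on HepG2 cells (Homo sapiens) for cytotoxicity, read by CellTiter-Glo and resazurin assay, with a stated time of 72 h (a higher number here means that more compound is needed for the effect, a lower number that less compound is needed), gives > 26000 nM, which is a limit of the assay rather than a number.
Compound 2, `CC(C)COc1cccc(-c2ccc(C(=O)N(Cc3cccc(OCCCCCC(=O)O)c3)C(C)C)cc2)c1`, in this assay gives > 26000 nM, again a limit of the assay.
Compound 3, `CC(C)N(Cc1cccc(OCCCCCC(=O)O)c1)C(=O)c1ccc(-c2ccc3[nH]ccc3c2)cc1`, in this assay gives > 26000 nM, also a limit of the assay.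

Compound 3 therefore stands nowhere in particular on the numbers shown: it sits at the limit, and the two other values shown sit at the same limit, as summarised by the limit of > 26000 nM in this assay, at which 3 of the 3 values shown sit. The steps that lead to compound 3 are a step that the two limits leave unreadable from compound 1 to compound 3 and a step that the two limits leave unreadable from compound 2 to compound 3; neither can be read, since both ends are limits.

Compound 4, `CC(C)N(Cc1cccc(OCCCCCC(=O)O)c1)C(=O)c1ccc(-c2cccc([N+](=O)[O-])c2)cc1`, has not been measured in this assay. Its difference from compound 3 is 3-nitrophenyl in place of 1H-indol-5-yl on an aromatic carbon. The measured steps that bear on it are the two just named: the exchange of one aryl group for another on the same aromatic carbon of the shared core, and in both cases the value stayed at the limit. No readable step is available, so nothing in the data points to a change beyond the scatter in either direction.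

Compound 4 is therefore expected to give 30000 nM in this assay, within 13000 nM to 100000 nM, most likely reported again as a limit. The step this estimate implies, a step that the limit leaves unreadable from compound 3 to compound 4, is expected to be within the scatter.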

Compound 4, half-maximal effective concentration: > 26000 nM
Compound 4 gave a limit, no number; the forecaster's own chance of this, stated with the estimate: 85%; the middle value is on the limit's open side.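

In this assay compound 4 gives a limit and no number, so the steps to it from compound 1, compound 2 and compound 3 cannot be read: the limit of > 26000 nM in this assay, at which 4 of the 4 values shown sit.

The compounds shown leave open what number any of the four would give in this assay, and whether any exchange on the shared core changes it.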